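The source may hold more compounds than are shown below. What is called first, only, known or untested is meant among the compounds shown, and "the series" means these compounds.

Among the compounds with values here, compound 2 `O=C1N=C(N2CCC[C@H]2C(=O)Nc2ccc3ncnc(Nc4cccc(Cl)c4)c3c2)S/C1=C/c1ccc(-c2ccccc2)cc1` is the only compound here with a measured number in a functional assay on HepG2 cells (Homo sapiens) for antiproliferative activity, read by MTT assay; a lower number here means a stronger inhibitor, a higher number a weaker inhibitor; in that assay compound 2 gives 15400 nM. Compound 1 `O=C1N=C(N2CCC[C@H]2C(=O)Nc2ccc3ncnc(Nc4cccc(Cl)c4)c3c2)S/C1=C/c1ccc(Br)s1` reaches only a limit of the assay, giving > 50000 nM. Within the data shown here, the single measured step, an at least 3.2-fold lower number from compound 1 to compound 2 (0.51 log units; beyond the scatter), is the sole guide. Compound 3 `O=C1N=C(N2CCC[C@H]2C(=O)Nc2ccc3ncnc(Nc4cccc(Cl)c4)c3c2)S/C1=C/c1cccnc1Cl` carries the change (2-chloropyridin-3-yl in place of 4-phenylphenyl on a double-bonded chain carbon bound to a double-bonded ring carbon). The entering group is a single ring, like the 5-bromothiophen-2-yl of compound 1, rather than the two rings of 4-phenylphenyl, so a move toward weaker inhibition is expected, a 1.9-fold higher number from compound 2 to compound 3 (0.29 log units; within the scatter), possibly ending again at a limit (the limit of > 50000 nM in this assay, at which 1 of the 2 values shown sits). Compound 3 is estimated at 30000 nM, between 10000 nM and 80000 nM.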

Compound 3, half-maximal inhibitory concentration: 6400 nM
Compound 3: the middle estimate sits 4.7-fold (0.67 log units) above what was measured; measured number outside the range, below it.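

In this assay, a smaller group at this position does not mean a weaker inhibitor: replacing the two rings of 4-phenylphenyl with the single ring of 2-chloropyridin-3-yl gives a 2.4-fold lower number from compound 2 to compound 3 (0.38 log units; beyond the scatter). The two single-ring groups also stand far apart, with an at least 7.8-fold lower number from compound 1 to compound 3 (0.89 log units; beyond the scatter), so ring count alone does not set the number. Compound 3 stays clear of the assay limit, which only compound 1 reaches: the limit of > 50000 nM in this assay, at which 1 of the 3 values shown sits.

From the compounds shown here alone, whether the ring nitrogen or the chlorine of 2-chloropyridin-3-yl matters more remains open. So does how a plain phenyl or a 4-aminophenyl would read here.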